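Swapping an Amide Link for an Ether in a Nitrophenyl Series

The compounds below may be only part of what the source reports. "The series", "measured", "known", "first", "only" and "open" are said of these compounds alone.

Of the compounds shown here, two sharing one core have been measured in a functional assay on PANC-1 cells (Homo sapiens) for inhibition, read by MTT assay, with a stated time of 24 h, tested at 10 uM; a higher number here means more inhibition at the concentration tested (going by the name of the read-out), a lower number less inhibition. Compound 1 `CC(C)=CCC/C(C)=C/CC1Cc2c(OCCCNC(=O)c3ccco3)cc(=O)n(CCCO)c2CC1(C)C` gives 69.5% in this assay. Among the compounds with values here, compound 2 `CC(C)=CCC/C(C)=C/CC1Cc2c(OCCCNC(=O)c3ccc([N+](=O)[O-])cc3)cc(=O)n(CCCO)c2CC1(C)C` gives 16.8% in this assay, the lowest of the two numbers; the only measured step, a number 52.7 percentage points lower from compound 1 to compound 2 (beyond the scatter), is large. Compound 3 `CC(C)=CCC/C(C)=C/CC1Cc2c(OCCCOc3ccc([N+](=O)[O-])cc3)cc(=O)n(CCCO)c2CC1(C)C` has not yet been measured. It differs from compound 2 in one place: 4-nitrophenoxy in place of ((4-nitrophenyl)carbonyl)amino on a saturated chain carbon, three bonds along the chain from an oxygen on an aromatic ring. Within the data shown here, the single measured step concerns a different change, the aromatic group on a carbonyl carbon, and leaves the amide linker itself in place, so nothing measured bears directly on replacing that amide with an ether while the same 4-nitrophenyl ring stays. Without a matching step to lean on, the expected step for compound 3 in this assay is estimated at a number 8.2 percentage points higher from compound 2 to compound 3 (within the scatter), small and of uncertain direction, with the low value of compound 2 as the starting point. Compound 3 is therefore expected to give about 25% in this assay, within a range from 5% to 50%.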

Compound 3, a percentage reported as inhibition, at one concentration (the size of the read-out at that concentration, not a potency): 65.1%
For compound 3 the middle estimate is 40.1 percentage points below the measured one; measured number above the stated range.
By their numbers in this assay, from the lowest: compound 2; then compounds 3 and 1 (each within the scatter of the next).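

In this assay, the 4-nitrophenyl ring does not by itself go with a low number: there is a number 48.3 percentage points higher from compound 2 to compound 3 (beyond the scatter) when 4-nitrophenoxy replaces ((4-nitrophenyl)carbonyl)amino on the saturated chain carbon. The earlier step changed only the aromatic group on the carbonyl carbon, so it could not show that the link carrying the same ring can decide the result, and the 4-nitrophenoxy group can also match the amide bearing furan-2-yl, with a number 4.4 percentage points lower from compound 1 to compound 3 (within the scatter) between those two compounds. No measurement at hand gives a reason for either step.

From the compounds shown here alone, this is one amide-to-ether swap on one ring, so it remains open whether the same swap would behave alike with a different aromatic group, such as a plain phenyl ring without the nitro group. Going by these compounds, it also remains open how a different link at this place, such as a secondary amine or a thioether, or a longer chain between the core and the ring, would read in this assay at the same concentration.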